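Swapping the terminal benzyl for a butylcarbamoyl group

A few compounds are considered here, and "the series" means these few. Any claim that something is new, unique, unknown or untested is made for them only; others in the source may bear on it.

Compound 1 `CC(C)(N)C(=O)N[C@H](COCc1ccccc1)c1nnnn1CCCc1ccccc1`: 200 nM
Compound 2 `CN(c1ccccc1CCCn1nnnc1[C@@H](COCc1ccccc1)NC(=O)C(C)(C)N)S(C)(=O)=O`: 1720 nM
Compound 3 `COC(=O)C(c1ccccc1)n1nnc([C@@H](COCc2ccccc2)NC(=O)C(C)(C)N)n1`: > 5000 nM

In an assay on isolated protein for displacement of a labelled ligand from growth hormone secretagogue receptor type 1 (Homo sapiens), with a stated time of 1 h (on this read-out higher numbers stand for weaker inhibition and lower numbers for stronger inhibition), compound 1 has the lowest of the two numbers shown. For compound 3 the value > 5000 nM is a limit of the assay, not a number. Within the data shown here, the one measured single-point step, an 8.6-fold higher number from compound 1 to compound 2 (0.93 log units; beyond the scatter), decorated the outer phenyl ring and weakened binding. Compound 4 `CCCCNC(=O)CCn1nnnc1[C@@H](COCc1ccccc1)NC(=O)C(C)(C)N` differs from compound 1 by butylcarbamoyl in place of benzyl on a saturated chain carbon, two bonds along the chain from an aromatic nitrogen. Among the measured compounds shown here, no measured step covers such a removal of the ring, so the expectation rests only on the outer chain appearing sensitive to change in this assay. A loss of modest size is expected, a 3.0-fold higher number from compound 1 to compound 4 (0.48 log units; beyond the scatter), and compound 4 is estimated at 600 nM (range 150 nM to 2500 nM).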

Compound 4, inhibition constant: 2190 nM
Compound 4: middle estimate off by 3.7-fold (0.56 log units), on the low side; the range from low to high includes it.
By their numbers in this assay, from the lowest: compound 1; then compounds 2 and 4 (each within the scatter of the next). At a limit, above all of these: compound 3.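

In this assay, exchanging the benzyl for butylcarbamoyl gives an 11-fold higher number from compound 1 to compound 4 (1.04 log units; beyond the scatter), so losing the outer aromatic ring altogether is a large change at this position. The two groups hold the same count of heavy atoms, so that count alone does not preserve binding here. Nothing measured here explains the loss.

As far as these compounds go, whether binding depends on the aromatic ring or is harmed by the carbamoyl stays open. A plain hexyl chain or a cyclohexyl ring in place of the benzyl would help separate the two.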